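A few compounds are considered here, and "the series" means these few. Any claim that something is new, unique, unknown or untested is made for them only; others in the source may bear on it.

The measured compounds:
compound 1, `COc1cccc(NC(=O)CCc2nc(Cc3ccc(NC(C)=O)cc3)no2)c1`, 35.6%
compound 2, `CC(=O)Nc1ccc(Cc2noc(CCC(=O)Nc3ccc(F)cc3)n2)cc1`, 64.4%
compound 3, `C#Cc1cccc(NC(=O)CCc2nc(Cc3ccc(NC(C)=O)cc3)no2)c1`, 84.9%

All three share one core and differ only in the group on the amide-type nitrogen. In a functional assay on the whole organism (strain C57BL/6) for inhibition, with Mus musculus as the target, read by paw edema, with stated times of 1 h and 4 h, at a dose of 100 mg/kg by the oral route (on this read-out higher numbers stand for more inhibition at the one dose given (going by the name of the read-out) and lower numbers for less inhibition), compound 3 gives 84.9%, the highest of the three numbers; compound 2 gives 64.4% and compound 1 gives 35.6%. The step of a number 20.5 percentage points higher from compound 2 to compound 3 (beyond the scatter) and the step of a number 49.3 percentage points higher from compound 1 to compound 3 (beyond the scatter) are both beyond the scatter, so compound 3 stands clearly above the other two.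

Compound 4, `CC(=O)Nc1ccc(Cc2noc(CCC(=O)Nc3cccnc3)n2)cc1`, has not yet been measured. Its change from compound 3 is pyridin-3-yl in place of 3-ethynylphenyl on an amide-type nitrogen. For the measured compounds named here, no measured step involves a pyridin-3-yl group, so the steps that bear on this change do so only indirectly: a number 20.5 percentage points higher from compound 2 to compound 3 (beyond the scatter) and a number 49.3 percentage points higher from compound 1 to compound 3 (beyond the scatter) show that the two other groups tried on the amide-type nitrogen gave lower numbers than 3-ethynylphenyl, one by a modest and one by a large margin. Compound 4 is therefore expected to fall below compound 3, with the step of a number 34.9 percentage points lower from compound 3 to compound 4 (beyond the scatter) expected to lie beyond the scatter, though whether it lands nearer the number of compound 1 or of compound 2 is uncertain. The estimate for compound 4 in this assay is 50%, with a range from 25% to 75%.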

Compound 4, a percentage reported as inhibition, in the whole organism at one dose (the size of the read-out at that dose, not a potency): 87.7%
Estimate against measurement, compound 4: 37.7 percentage points below; the whole stated range lies below it.
By their numbers in this assay, from the lowest: compound 1; then compound 2; then compounds 3 and 4 (each within the scatter of the next).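

In this assay, the step of a number 2.8 percentage points higher from compound 3 to compound 4 (within the scatter) lies within the scatter, so on this amide-type nitrogen a pyridin-3-yl group, which has a ring nitrogen and a hydrogen-bond acceptor and no triple bond, reads on a level with 3-ethynylphenyl. The high number is thus not tied to 3-ethynylphenyl or its triple bond, yet not every aromatic group reaches it: the step of a number 23.3 percentage points higher from compound 2 to compound 4 (beyond the scatter) and the step of a number 52.1 percentage points higher from compound 1 to compound 4 (beyond the scatter) both lie beyond the scatter and leave 4-fluorophenyl and 3-methoxyphenyl lower. Nothing given here explains why two such different groups read alike.

The compounds shown leave open whether pyridin-2-yl, pyridin-4-yl or plain phenyl on the same nitrogen would match pyridin-3-yl, and whether an amine or a carboxylic acid on that ring would keep the number high. Each compound also has a reading at only one dose, so these numbers give the size of the effect at that dose and leave open how compound 3 and compound 4 would compare at lower doses.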